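The source may hold more compounds than are shown below. What is called first, only, known or untested is meant among the compounds shown, and "the series" means these compounds.

Measured in an in vitro functional assay on Sf9 cells for antagonist activity at histamine H2 receptor (Homo sapiens); on this read-out lower numbers stand for lower potency and higher numbers for higher potency (the scale is a negative logarithm):
Compound 1, `CC(CCN/C(=N\C#N)NCCCCc1c[nH]cn1)c1ccccc1`, gives < 5, which is a limit of the assay.
Compound 2, `CCN/C(=N\C#N)NCCCCc1c[nH]cn1`, gives < 5, also a limit of the assay.
Compound 3, `N#C/N=C(\NCCCCCc1c[nH]cn1)NCCSc1ccccc1`, gives 5.21.

Within the data shown here, compound 3 thus stands as the only compound here with a number in this assay; the other two values are limits, (the limit of < 5 in this assay, at which 2 of the 3 values shown sit). The step from compound 1 to compound 2 is a step that the two limits leave unreadable from compound 1 to compound 2, so its size cannot be read. Compound 4, `CCN/C(=N/C#N)NCCCCCc1c[nH]cn1`, has not been measured in this assay. It differs from compound 3 by hydrogen in place of phenylsulfanyl on a saturated chain carbon, two bonds along the chain from an amine nitrogen. Among the measured compounds shown here, the one measured step that resembles this change, the one from compound 1 to compound 2, removes a phenyl-bearing group at the same kind of position, but both of its ends are limits and it shows no size. The expectation for compound 4 therefore rests mainly on where compound 3 stands with 5.21. Compound 4 is expected to give 4.8, between 4.2 and 5.3, with a real chance that only a limit is reported. The expected step is a number 0.41 log units lower from compound 3 to compound 4 (beyond the scatter), downward, and not clearly beyond the usual scatter.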

Compound 4, negative logarithm of the antagonist equilibrium constant: 5.37
Compound 4: the middle estimate sits 0.57 log units below what was measured; measured number outside the range, above it.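

In this assay, the replacement of phenylsulfanyl by hydrogen on a saturated chain carbon, two bonds along the chain from an amine nitrogen, comes out as a number 0.16 log units higher from compound 3 to compound 4 (within the scatter), which gives this kind of change its first readable size. The group that leaves has 7 heavy atoms, including a six-membered aromatic ring of carbon only, yet in this pair the two compounds cannot be told apart, so here the phenylsulfanyl group shows no measurable contribution to the read-out. The earlier step at this kind of position cannot be read, and only compound 3 and compound 4 now carry numbers, while the other values stay at a limit: the limit of < 5 in this assay, at which 2 of the 4 values shown sit.

As far as these compounds go, this is a single pair, so it remains open whether the same replacement would give a similar result on a shorter chain or with a longer chain joining the core to the amine nitrogen. From the compounds shown here alone, it is also open how an amine, a carboxylic acid or a phenoxy group at the same place would compare with hydrogen.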